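This account rests on a few compounds, and the source may have more. Where it says the series, first, only, none or still open, it means among the compounds named here.

In a functional assay on ileum (Cavia porcellus) for inhibition (a lower number here means a stronger inhibitor, a higher number a weaker inhibitor), two compounds built on the same kind of core have been measured so far. Compound 1 (`COC(=O)C1=C(C)NC(C)=C(C(=O)OC)C1c1c(-c2c(Cl)csc2Cl)nc2sc(C)cn12`) gives 3230 nM and compound 2 (`COC(=O)C1=C(C)NC(C)=C(C(=O)OC)C1c1c(-c2cccnc2)nc2sccn12`) gives 3550 nM. These two numbers lie within the usual scatter of repeated measurements, so neither can be called the stronger inhibitor.

Compound 3 (`COC(=O)C1=C(C)NC(C)=C(C(=O)OC)C1c1c(-c2c(Cl)csc2Cl)nc2sccn12`) has not yet been measured. Compared with compound 2, it loses the pyridin-3-yl group and gains a chlorine-bearing five-membered ring containing sulfur: a group of 7 heavy atoms (4 carbon, 1 sulfur, 2 chlorine; one five-membered aromatic ring with 1 hetero atom) in place of a group of 6 heavy atoms (5 carbon, 1 nitrogen; one six-membered aromatic ring with 1 hetero atom), on an aromatic carbon. The change sits on an aromatic carbon of the shared core.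

Among the compounds with values here, no measured pair isolates this change, so any forecast is tentative. Within the data shown here, the entering group also appears in compound 1, which gives 3230 nM, and this offers the only guide. No change beyond the scatter is therefore expected in this assay, and the estimated move is small: a 1.2-fold lower number from compound 2 to compound 3 (0.07 log units; within the scatter). For compound 3 the expected value is 3000 nM, with an estimated range from 900 nM to 10000 nM.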

Compound 3, half-maximal inhibitory concentration: 180 nM
Compound 3: the middle estimate sits 17-fold (1.22 log units) above what was measured, and the stated range ends above it.
By their numbers in this assay, from the lowest: compound 3; then compounds 1 and 2 (each within the scatter of the next).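

In this assay, replacing pyridin-3-yl with the chlorine-bearing five-membered ring containing sulfur, on an aromatic carbon of the shared core, brings a large gain (a 20-fold lower number from compound 2 to compound 3 (1.29 log units; beyond the scatter)), so this position is sensitive to which ring it carries. Removing one small group has a similar effect: hydrogen in place of methyl on an aromatic carbon gives (an 18-fold lower number from compound 1 to compound 3 (1.25 log units; beyond the scatter)), which shows that compound 1 owed its weak result to that methyl and not to its chlorinated ring, and that the match between compound 1 and compound 2 had hidden two separate large effects. Nothing available explains why either change matters so much.

The compounds shown leave open whether the methyl would cost as much alongside pyridin-3-yl, since only the chlorinated ring has been seen both with and without it. They also leave open which part of the entering ring carries the gain, which a plain phenyl ring or a thiophene without its chlorines could help to settle, and whether an ethyl group or a fluorine in place of the methyl would be tolerated.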